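Nitro for tert-butyl on a hydrazone-linked triazole

The compounds below may be only part of what the source reports. "The series", "measured", "known", "first", "only" and "open" are said of these compounds alone.

Of the compounds shown here, two sharing one core have been measured in an assay for inhibition of Alpha amylase (Homo sapiens), with a stated time of 10 min; a lower number here means a stronger inhibitor, a higher number a weaker inhibitor. Compound 1 is `Oc1ccc(/C=N/n2cnnc2)c(O)c1O` and in this assay compound 1 gives 5920 nM. Compound 2 is `CC(C)(C)c1ccc(/C=N/n2cnnc2)cc1` and in this assay compound 2 gives 6440 nM. These two numbers lie within the usual scatter of each other, so neither compound can be called the stronger or weaker inhibitor on this evidence; compound 2 sits alongside compound 1 rather than apart from it.

Compound 3 is `O=[N+]([O-])c1ccc(/C=N/n2cnnc2)cc1`. The change from compound 2 to compound 3 is nitro in place of tert-butyl on an aromatic carbon. Within the data shown here, no measured pair here shows what such a swap does, so there is no step to lean on. Given that the two measured compounds differ in their substituents yet land close together, the expectation is a step of a 1.1-fold lower number from compound 2 to compound 3 (0.03 log units; within the scatter), that is, no change beyond the scatter in either direction. Compound 3 is therefore expected to give about 6000 nM in this assay, with a plausible range from 2000 nM to 18000 nM.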

Compound 3, half-maximal inhibitory concentration: 2360 nM
For compound 3 the middle estimate is 2.5-fold (0.41 log units) above the measured one, within the range that was stated.
By their numbers in this assay, from the lowest: compound 3; then compounds 1 and 2 (each within the scatter of the next).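

In this assay, among these compounds, compound 2 and compound 3 form the first pair here that differs in one place only, which makes it possible to read the effect of a single change on the shared core. On the aromatic carbon para to a group of 7 heavy atoms, nitro in place of tert-butyl gives a 2.7-fold lower number from compound 2 to compound 3 (0.44 log units; beyond the scatter) and this modest step shows that the group at this position can shift the number beyond the scatter. The change swaps a group of carbon atoms with 0 hydrogen-bond acceptors for one of nitrogen and oxygen with 2 hydrogen-bond acceptors, but no measurement here links the step to either difference or explains it.

On these data alone, with a single pair at this position, it remains open whether the lower number is particular to nitro or would also appear with other groups on this carbon. A nitrile, an amine or a carboxylic acid at this position would show whether the trend continues or reverses, and nitro on a different carbon of the ring would show how much the place matters as well as the group.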